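Carbamate in place of acetamide on the shared core

The source may report more compounds than this note shows. Statements on the series, on what has been measured and on what is new or still open speak of the compounds shown alone.

Compound 1 `CC(C)S(=O)(=O)Nc1cccc2c1CCCC2c1c[nH]cn1` carries an isopropylsulfonyl group on the ring nitrogen, and in an assay on isolated protein for binding affinity to Alpha-1D adrenergic receptor (Rattus norvegicus), read by radioligand binding (on this read-out higher numbers stand for weaker inhibition and lower numbers for stronger inhibition), compound 1 gives 2040 nM. Compound 2 `O=S(=O)(Nc1cccc2c1CCCC2c1c[nH]cn1)C1CC1` gives 2690 nM in this assay, and a 1.3-fold higher number from compound 1 to compound 2 (0.12 log units; within the scatter). For the measured compounds named here, compound 3 `CC(=O)Nc1cccc2c1CCCC2c1c[nH]cn1` has in this assay only a limit, < 10000 nM, so compound 3 stands on a limit rather than a number, the one value of the three that sits at the limit of < 10000 nM in this assay, at which 1 of the 3 values shown sits. Accordingly a step that the limit leaves unreadable from compound 1 to compound 3 and a step that the limit leaves unreadable from compound 2 to compound 3. Compound 4 `COC(=O)Nc1cccc2c1CCCC2c1c[nH]cn1` differs from compound 3 by methoxy in place of methyl on a carbonyl carbon. Going by the values given here, no measured step touches the carbonyl carbon; the two steps that bear on the acyl region are the unreadable ones to compound 3, and they give no size. The account therefore expects, in this assay, no step beyond the scatter, and the expected step is a step that the limit leaves unreadable from compound 3 to compound 4. Compound 4 is estimated at 5000 nM in this assay, within a range from 1500 nM to 15000 nM.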

Compound 4, inhibition constant: 3020 nM
For compound 4 the middle estimate is 1.7-fold (0.22 log units) above the measured one, and the stated range covers the measured number.
By their numbers in this assay, from the lowest: compounds 1, 2 and 4 (each within the scatter of the next).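

In this assay, methoxycarbonyl on a nitrogen on an aromatic ring gives a readable number, and against the two sulfonyl groups the result is a 1.1-fold higher number from compound 2 to compound 4 (0.05 log units; within the scatter) and a 1.5-fold higher number from compound 1 to compound 4 (0.17 log units; within the scatter). Among compound 1, compound 2 and compound 4, a readable number at this position therefore does not depend on a sulfonyl group, since exchanging either one for methoxycarbonyl stays within the scatter. The steps that touch compound 3, including methoxy in place of methyl on the carbonyl carbon, cannot be read, because compound 3 stands on a limit: the limit of < 10000 nM in this assay, at which 1 of the 4 values shown sits.

The compounds shown leave open whether a dimethylamino group on the carbonyl carbon, or an ethoxy or longer alkoxy chain in place of methoxy, would keep the number in this range. They also leave open what the free amine on the aromatic ring would give in this assay.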